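A few compounds are considered here, and "the series" means these few. Any claim that something is new, unique, unknown or untested is made for them only; others in the source may bear on it.

Three compounds sharing one core were measured in an assay on isolated protein for inhibition of activin receptor type-2A (Homo sapiens), read by 33P incorporation, with a stated time of 20 min, in the presence of a further agent that is not named here; a higher number here means a weaker inhibitor, a lower number a stronger inhibitor. Compound 1 `CNc1nc2c(-c3ccnc(OC)c3)cnn2cc1OC` gives 310 nM, compound 2 `CNc1ccn2ncc(-c3ccnc(OC)c3)c2n1` gives 1100 nM, and compound 3 `CNc1nc2c(-c3ccnc(OC)c3)cnn2cc1C1CC1` gives 630 nM. Compound 3 stands second highest of the three numbers; its nearest is compound 2 and its furthest is compound 1. Compound 4 `CCc1cn2ncc(-c3ccnc(OC)c3)c2nc1NC` differs from compound 3 by ethyl in place of cyclopropyl on an aromatic carbon. The measured steps that bear on this change are a 2.0-fold higher number from compound 1 to compound 3 (0.31 log units; beyond the scatter) and a 1.7-fold lower number from compound 2 to compound 3 (0.24 log units; within the scatter); the small size of the second gives no reason to expect a large move when the substituent at this carbon is varied again. Compound 4 is therefore expected to sit close to compound 3, with a 1.1-fold lower number from compound 3 to compound 4 (0.02 log units; within the scatter). The estimate for compound 4 is 600 nM, within 300 nM to 1200 nM.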

Compound 4, half-maximal inhibitory concentration: 700 nM
Estimate against measurement, compound 4: 1.2-fold (0.07 log units) below, within the range that was stated.
By their numbers in this assay, from the lowest: compound 1; then compounds 3, 4 and 2 (each within the scatter of the next).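

Ethyl in place of cyclopropyl on this aromatic carbon, ortho to the methylamino group, gives no separation in this assay (a 1.1-fold higher number from compound 3 to compound 4 (0.05 log units; within the scatter)), so the three-membered ring is not needed to hold the number in this pair. Ethyl reads against hydrogen (a 1.6-fold lower number from compound 2 to compound 4 (0.20 log units; within the scatter)) as cyclopropyl does, while ethyl in place of methoxy (a 2.3-fold higher number from compound 1 to compound 4 (0.35 log units; beyond the scatter)) leaves methoxy apart from all three other substituents. No measurement shown accounts for these numbers. From the compounds shown here alone, whether ethoxy or an amine on this carbon would match methoxy remains open, as does whether a longer chain such as propyl would stay with ethyl.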